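The source may hold more compounds than are shown below. What is called first, only, known or untested is meant among the compounds shown, and "the series" means these compounds.

Compound 1 `NS(=O)(=O)c1ccc(Nc2nccc(Nc3ccc4cn[nH]c4c3)n2)cc1` gives 22000 nM in an ADME assay on HepG2 cells (Homo sapiens) for inhibition, read by fluorescence and resazurin assay, with a stated time of 72 h; a higher number here means a weaker inhibitor, a lower number a stronger inhibitor.
Compound 2 `Cc1cccc(Nc2nccc(Nc3ccc4nc[nH]c4c3)n2)c1` gives 20000 nM in this assay.
Compound 3 `Cc1cccc(Nc2ncc([N+](=O)[O-])c(Nc3ccc4nc[nH]c4c3)n2)c1` gives 22000 nM in this assay.

Compound 3 stands level with compound 1 at the digits shown, and its value sits within the scatter of compound 2 as well; the three measured numbers cannot be told apart. Going by the values given here, the one step among them that can be followed, a 1.1-fold higher number from compound 2 to compound 3 (0.04 log units; within the scatter), is a change within the scatter.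

Compound 4 `Cc1cccc(Nc2ncc(C)c(Nc3ccc4nc[nH]c4c3)n2)c1` differs from compound 3 in one place: methyl in place of nitro on an aromatic carbon. Among the compounds with values here, the only measured step that touches this position is a 1.1-fold higher number from compound 2 to compound 3 (0.04 log units; within the scatter), which brought a nitro group onto the same aromatic carbon without moving the number beyond the scatter. Nothing in the data shows that group to matter for this assay, and replacing it with a methyl is expected to leave the value where the three measured compounds already sit; the expected step of a 1.1-fold lower number from compound 3 to compound 4 (0.04 log units; within the scatter) is no change beyond the scatter. Compound 4 is therefore estimated at 20000 nM, with a range from 8000 nM to 50000 nM.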

Compound 4, half-maximal inhibitory concentration: 6600 nM
Compound 4: the middle estimate sits 3.0-fold (0.48 log units) above what was measured, outside the stated range (below it).
By their numbers in this assay, from the lowest: compound 4; then compounds 2, 1 and 3 (each within the scatter of the next).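

The aromatic carbon para to the (3-methylphenyl)amino group is not indifferent in this assay after all: methyl in place of nitro gives a 3.3-fold lower number from compound 3 to compound 4 (0.52 log units; beyond the scatter), and methyl in place of hydrogen gives a 3.0-fold lower number from compound 2 to compound 4 (0.48 log units; beyond the scatter). Both steps are modest but beyond the scatter, and each points to a stronger inhibitor. Since hydrogen and nitro remain within the scatter of each other, merely placing a group on this carbon does not shift the number; among these three groups, only methyl stands apart.

The compounds shown leave open whether an ethyl, a methoxy or an amine on this carbon would track with methyl or stay with hydrogen and nitro. No measurement offered here accounts for the difference seen with methyl.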